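Replacing Iodo with Bromo on Compound 2

A few compounds are considered here, and "the series" means these few. Any claim that something is new, unique, unknown or untested is made for them only; others in the source may bear on it.

Of the compounds shown here, two have been measured so far in an in vivo ADME assay on the whole organism for pharmacokinetics, with Rattus norvegicus as the target, at a dose of 1 mg/kg by the intravenous route; a higher number here means that more of the compound sits outside the plasma, a lower number that more of the compound stays in the plasma. Compound 1 (`O=C(NOC[C@H](O)CO)c1ccc2cnsc2c1Nc1ccc(I)cc1F`) gives 0.97 L/kg, and compound 2 (`O=C(NOCCO)c1ccc2[nH]ncc2c1Nc1ccc(I)cc1F`) gives 2.4 L/kg. Compound 2 therefore holds the higher of the two numbers, and the gap lies beyond the usual scatter of repeated measurements. These two compounds differ in more than one place, so their gap cannot be pinned on any single change.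

Compound 3 (`O=C(NOCCO)c1ccc2[nH]ncc2c1Nc1ccc(Br)cc1F`) departs from compound 2 at just one group: bromo in place of iodo on an aromatic carbon. The rest of the structure stays the same. Within the data shown here, no pair of measured compounds shows this swap, so the data offer no direct guide to its effect. With only one halogen exchanged for another, a small step, slightly downward and not beyond the scatter, is expected in this assay. The expected change is a 1.2-fold lower number from compound 2 to compound 3 (0.08 log units; within the scatter). For compound 3, the estimate is 2 L/kg, with a range of 1.1 L/kg to 3.6 L/kg.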

Compound 3, volume of distribution at steady state: 1.5 L/kg
Estimate against measurement, compound 3: 1.3-fold (0.12 log units) above; the range from low to high includes it.
By their numbers in this assay, from the lowest: compounds 1, 3 and 2 (each within the scatter of the next, the first and the last beyond it).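

Among these compounds, exchanging iodo for bromo on the aromatic ring gives the first comparison of compounds differing in one place in this assay, and it reads as a 1.6-fold lower number from compound 2 to compound 3 (0.20 log units; within the scatter). At this position, para to a large group and meta to a fluoro group, compound 2 and compound 3 therefore cannot be told apart, even though the swap from 2-fluoro-4-iodophenyl to 4-bromo-2-fluorophenyl replaces one halogen with another. Nothing measured here connects the result to any property of either halogen.

On these data alone, it remains open whether a group other than these two halogens at the same position, such as chloro, methyl or a nitrile, would give a step beyond the scatter. Also open, as far as these compounds go, is whether bromo in place of iodo would give a similar step on compound 1, whose core and side chain both differ from those of compound 2, so this single pair cannot show whether the result holds beyond the core it shares.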